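The source may report more compounds than this note shows. Statements on the series, on what has been measured and on what is new or still open speak of the compounds shown alone.

Three compounds built on one shared core were tested in an assay on HEK293 cells for antagonist activity at P2X purinoceptor 7 (Homo sapiens), read by fluorescence, with a stated time of 2 h; a lower number here means a stronger inhibitor, a higher number a weaker inhibitor. Compound 1 `CS(=O)(=O)Oc1ccc(-c2cncn2C2CCN(C(=O)c3ccc(Cl)c(C(F)(F)F)c3)CC2)cc1` gives 1570 nM, and compound 2 `O=C(c1ccc(Cl)c(C(F)(F)F)c1)N1CCC(n2cncc2-c2ccc(OS(=O)(=O)c3ccccc3)cc2)CC1` gives 702 nM, the step being a 2.2-fold lower number from compound 1 to compound 2 (0.35 log units; beyond the scatter). Compound 3 `O=C(Oc1ccc(-c2cncn2C2CCN(C(=O)c3ccc(Cl)c(C(F)(F)F)c3)CC2)cc1)c1ccccc1` reaches only a limit of the assay, > 10000 nM. Compound 3 thus stands at the weak end of the three, at the limit of > 10000 nM in this assay, at which 1 of the 3 values shown sits. Compound 4 `Nc1cccc(S(=O)(=O)Oc2ccc(-c3cncn3C3CCN(C(=O)c4ccc(Cl)c(C(F)(F)F)c4)CC3)cc2)c1` differs from compound 3 by (3-aminophenyl)sulfonyl in place of benzoyl on an oxygen on an aromatic ring. The measured steps that bear on this are an at least 6.3-fold higher number from compound 1 to compound 3 (0.80 log units; beyond the scatter) and an at least 14-fold higher number from compound 2 to compound 3 (1.15 log units; beyond the scatter), both putting benzoyl in place of a sulfonyl group and both raising the number. Reversing that change is therefore expected to lower the number beyond the scatter, by about an at least 11-fold lower number from compound 3 to compound 4 (1.04 log units; beyond the scatter). Compound 4 is expected to give about 900 nM, between 300 nM and 3000 nM.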

Compound 4, half-maximal inhibitory concentration: 565 nM
Estimate against measurement, compound 4: 1.6-fold (0.20 log units) above; measured number inside the range.
By their numbers in this assay, from the lowest: compounds 4 and 2 (each within the scatter of the next); then compound 1. At a limit, above all of these: compound 3.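

A sulfonyl group on this oxygen again outdoes benzoyl, now with an amino group on its aromatic ring: an at least 17-fold lower number from compound 3 to compound 4 (1.24 log units; beyond the scatter). Amino in place of hydrogen on an aromatic carbon leaves the number within the scatter, a 1.2-fold lower number from compound 2 to compound 4 (0.09 log units; within the scatter), while the aromatic group's gain over methyl on the sulfonyl sulfur holds: a 2.8-fold lower number from compound 1 to compound 4 (0.44 log units; beyond the scatter). The number for compound 3 is a limit, so the first step has no exact size: the limit of > 10000 nM in this assay, at which 1 of the 4 values shown sits.

Still open, from the compounds shown here alone, is whether a carboxylic acid or a methoxy group in place of that amino group would keep this level. Going by these compounds, an ethyl or longer chain on the sulfonyl sulfur also remains open.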